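Putting 4-chlorophenyl on the amide nitrogen

The source may hold more compounds than are shown below. What is called first, only, known or untested is meant among the compounds shown, and "the series" means these compounds.

Measured in a functional assay on MCF7 cells (Homo sapiens) for antiproliferative activity, read by MTT assay, with a stated time of 72 h; a higher number here means a weaker inhibitor, a lower number a stronger inhibitor:
Compound 1 `CC(C)N1C(=O)COc2ccc(-c3cnc(Cl)c(NS(=O)(=O)c4ccc(F)cc4)c3)cc21`: 26600 nM
Compound 2 `O=C1COc2ccc(-c3cnc(Cl)c(NS(=O)(=O)c4ccc(F)cc4)c3)cc2N1`: > 40000 nM (a limit, not a number)

Compound 2 has no exact number on this scale, only the limit > 40000 nM. Compound 3 `O=C1COc2ccc(-c3cnc(Cl)c(NS(=O)(=O)c4ccc(F)cc4)c3)cc2N1c1ccc(Cl)cc1` carries 4-chlorophenyl in place of hydrogen on an amide-type nitrogen in a ring. Going by the values given here, only one measured step touches this nitrogen: an at least 1.5-fold higher number from compound 1 to compound 2 (0.17 log units; that floor lies within the scatter), where hydrogen replaces isopropyl. That step gives only a floor, and the floor lies within the scatter, so it is weak guidance. Because compound 1 gives 26600 nM with isopropyl on that nitrogen, a modest move to a lower number is expected in this assay when a group returns there. The estimated step is an at least 2.0-fold lower number from compound 2 to compound 3 (0.30 log units; that floor lies within the scatter). For compound 3 the expected value is 20000 nM, with an estimated range of 7000 nM to 40000 nM.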

Compound 3, half-maximal inhibitory concentration: 32800 nM
Estimate against measurement, compound 3: 1.6-fold (0.21 log units) below; low and high end bracket the measured number.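

In this assay, two quite different groups on this amide-type nitrogen in a ring, the branched isopropyl and the aromatic 4-chlorophenyl, cannot be told apart: a 1.2-fold higher number from compound 1 to compound 3 (0.09 log units; within the scatter). Measured against the bare nitrogen, the change reads an at least 1.2-fold lower number from compound 2 to compound 3 (0.08 log units; that floor lies within the scatter), so a real gain from adding 4-chlorophenyl there can be neither claimed nor ruled out. That step is only a floor because compound 2 has no exact number, just a limit: the limit of > 40000 nM in this assay, at which 1 of the 3 values shown sits.

From the compounds shown here alone, it remains open whether a group of another kind on this nitrogen, such as a short chain ending in an amine or a carboxylic acid, would move the number beyond the scatter. Also open, going by these compounds, is how far compound 2 truly lies from compound 1 and compound 3, since its exact value is unknown.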